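Moving the Methylpyrazole Attachment Point on Two Urea Cores

This account rests on a few compounds, and the source may have more. Where it says the series, first, only, none or still open, it means among the compounds named here.

Compound 1 `CSc1cc(C)nc(SC)c1NC(=O)N(Cc1ccccc1)Cc1cccc(-c2ccnn2C)c1` carries a 1-methyl-1H-pyrazol-5-yl group on one arm. In a functional assay on a cell-free system (plasma) with sterol O-acyltransferase, Soat (Rattus norvegicus) as the target (a higher number here means that more compound is needed for the effect, a lower number that less compound is needed), compound 1 gives < 1 mg/kg, which is a limit of the assay rather than a number. Compound 2 `CSc1cc(C)nc(SC)c1NC(=O)N(Cc1ccccc1)Cc1cccc(-c2cnn(C)c2)c1` differs by 1-methyl-1H-pyrazol-4-yl in place of 1-methyl-1H-pyrazol-5-yl on an aromatic carbon. In this assay compound 2 gives > 0.1 mg/kg, again a limit. The step that the limit leaves unreadable from compound 1 to compound 2 therefore cannot be sized; the two values show only where each sits, as the limit of < 1 mg/kg in this assay, at which 2 of the 3 values shown sit, and the limit of > 0.1 mg/kg in this assay, at which 1 of the 3 values shown sits, record. Compound 3 `Cc1cc(C)c(NC(=O)N(Cc2ccc(-c3ccnn3C)cc2)C2CCCCCC2)c(C)c1` has a different core, and the difference between the two cores is not broken down here. In this assay compound 3 gives < 1 mg/kg, a limit. Compound 4 `Cc1cc(C)c(NC(=O)N(Cc2ccc(-c3cnn(C)c3)cc2)C2CCCCCC2)c(C)c1` makes the same kind of change, (1-methyl-1H-pyrazol-4-yl in place of 1-methyl-1H-pyrazol-5-yl on an aromatic carbon), but the place is para to a large group rather than meta to it. The step of a number no lower from compound 3 to compound 4 (the limit leaves the size open) is expected to be small, because the measured step that the limit leaves unreadable from compound 1 to compound 2 could not be sized. Compound 4 is expected to give 1 mg/kg in this assay, with a range from 0.2 mg/kg to 5 mg/kg.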

Compound 4, dose for half-maximal effect: 0.31 mg/kg
Beside the measured number, compound 4's estimate is 3.2-fold (0.51 log units) above it; the measured number falls inside the stated range.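

No step can be read from compound 3 to compound 4, because compound 3 stands only at a limit: the limit of < 1 mg/kg in this assay, at which 2 of the 4 values shown sit. The compounds shown leave open how far 1-methyl-1H-pyrazol-4-yl in place of 1-methyl-1H-pyrazol-5-yl shifts the dose on either core.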